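The compounds below may be only part of what the source reports. "The series", "measured", "known", "first", "only" and "open" are said of these compounds alone.

Compound 1 `COC1=C(C)C(=O)/C(=C(O)/C=C/c2ccc(C)cc2)C(=O)C1(C)C` and compound 3 `CCC1=C(OC)C(CC)(CC)C(=O)C(C(=O)/C=C/c2ccc(C)cc2)=C1O` are built on two different cores; how the two cores differ is not broken down here. In a functional assay on A549 cells (Homo sapiens) for cytotoxicity (a lower number here means that less compound is needed, a higher number that more compound is needed for the effect), compound 1 gives 4.3 ug/mL and compound 3 gives 4.6 ug/mL, and these two numbers lie within the usual scatter of each other. Compound 2 `CCc1ccc(/C=C/C(O)=C2/C(=O)C(C)=C(OC)C(C)(C)C2=O)cc1` is compound 1 with a single change, (methyl in place of hydrogen on a saturated chain carbon bound to an aromatic carbon), and in this assay compound 2 gives 6.1 ug/mL. That change made a 1.4-fold higher number from compound 1 to compound 2 (0.15 log units; within the scatter), a step that cannot be told apart from the noise of repeated measurements.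

Compound 4 `CCC1=C(OC)C(CC)(CC)C(=O)C(C(=O)/C=C/c2ccc(CC)cc2)=C1O` has not been measured. For the measured compounds named here, it differs from compound 3 by methyl in place of hydrogen on a saturated chain carbon bound to an aromatic carbon, and the place of the change reads the same way in both pairs, so this is the same change as the one made from compound 1 to compound 2. Among the four compounds it appears twice, and the one measured example gave only a small step. For compound 4 the expected step is a 1.3-fold higher number from compound 3 to compound 4 (0.12 log units; within the scatter), which rests on a 1.4-fold higher number from compound 1 to compound 2 (0.15 log units; within the scatter) as the sole measured case of this change. The cores of compound 1 and compound 3 differ in more than one place, so carrying the step across is uncertain. The estimate for compound 4 in this assay is 6 ug/mL, expected to fall between 3 ug/mL and 12 ug/mL.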

Compound 4, concentration for half-maximal effect: 3.8 ug/mL
For compound 4 the middle estimate is 1.6-fold (0.20 log units) above the measured one; the range from low to high includes it.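

Going from 4-methylphenyl to 4-ethylphenyl on the core of compound 3 reads as a 1.2-fold lower number from compound 3 to compound 4 (0.08 log units; within the scatter) in this assay, so on this core, as on the core of compound 1, the step cannot be told apart from the noise of repeated measurements. Set side by side, the two steps point in opposite directions on paper, yet they do not differ by more than such steps normally would: the same change on two cores in this assay, a 1.4-fold higher number (0.15 log units; within the scatter) from compound 1 to compound 2 and a 1.2-fold lower number (0.08 log units; within the scatter) from compound 3 to compound 4, 1.7-fold (0.23 log units) apart, within the scatter of two such steps. This shows that, in these two pairs, the change stays too small to read on either core, and nothing here suggests that the cores treat it differently; it does not show that the change is without any effect, or that the two cores respond alike, as two small steps are a thin base and a slight real effect or a slight real difference between the cores could lie hidden in the scatter.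

The compounds shown carry only 4-methylphenyl and 4-ethylphenyl, which leaves open what a longer chain such as butyl, or a quite different group such as an amine or a carboxylic acid, would do in that place in this assay. Whether a change with a step large enough to read would carry from one core to the other in the same direction also remains an open question.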